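Swapping the pyridyl ester and its expected half-life

This account rests on a few compounds, and the source may have more. Where it says the series, first, only, none or still open, it means among the compounds named here.

Compound 2, `Cc1ncccc1OP(=O)(O)OC[C@H]1O[C@@H](n2cc(C)c(=O)[nH]c2=O)C[C@@H]1N=[N+]=[N-]`: 15.8 h
Compound 1, `O=c1ccn([C@H]2CC[C@@H](COP(=O)(O)Oc3cccnc3)O2)c(=O)[nH]1`: 50.2 h

Both were run in a physicochemical assay for metabolic stability, read by HPLC; a higher number here means that the compound lasts longer, a lower number that the compound disappears faster. Compound 2 has the lower of the two numbers in this assay; compound 1 sits higher, by a gap beyond the usual scatter. Compound 3, `Cc1cn([C@H]2C[C@H](N=[N+]=[N-])[C@@H](COP(=O)(O)Oc3ccncc3)O2)c(=O)[nH]c1=O`, has not yet been measured. It differs from compound 2 in one place: pyridin-4-yl in place of 2-methylpyridin-3-yl on an oxygen. For the measured compounds named here, no measured pair shows a change of this kind, so only a small step is expected, in either direction and probably within the scatter: a 1.3-fold higher number from compound 2 to compound 3 (0.10 log units; within the scatter). For compound 3 the estimate is 20 h, with a range from 8 h to 50 h.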

Compound 3, half-life: 8.07 h
The estimate for compound 3 lay 2.5-fold (0.39 log units) above the measured number, within the range that was stated.
By their numbers in this assay, from the lowest: compounds 3 and 2 (each within the scatter of the next); then compound 1.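

Putting pyridin-4-yl in place of 2-methylpyridin-3-yl on an oxygen gives a 2.0-fold lower number from compound 2 to compound 3 (0.29 log units; within the scatter) and so, at this position, the two groups cannot be told apart in this assay on this single pair. For the compounds shown here, it is the first direct reading of a change at this place, and it shows that this exchange of groups need not move the half-life beyond the scatter. No available evidence bears on what lies behind this result.

As far as these compounds go, whether a phenyl ring or an ethyl chain on that oxygen would stay as close to compound 2 remains open.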